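A few compounds are considered here, and "the series" means these few. Any claim that something is new, unique, unknown or untested is made for them only; others in the source may bear on it.

Measured in a functional assay on ileum (Cavia porcellus) for antagonist activity; a lower number here means a stronger inhibitor, a higher number a weaker inhibitor:

- compound 1 `Cc1ccc(CCCCOc2ccc3c(O)c([N+](=O)[O-])c(=O)oc3c2)cc1`: 2500 nM
- compound 2 `CCc1cc2c(O)c([N+](=O)[O-])c(=O)oc2cc1OCCCOc1ccccc1`: > 10000 nM (a limit)
- compound 3 `CC(=O)c1ccc(OCCCOc2ccc3c(O)c([N+](=O)[O-])c(=O)oc3c2)cc1`: 6100 nM

Compound 2 reached only a limit of the assay. Compound 3, at 6100 nM, has the higher of the two true numbers, and its gap to compound 1 lies beyond the usual scatter. Compound 4 `O=c1oc2cc(OCCCOc3ccc(-c4ccccc4)cc3)ccc2c(O)c1[N+](=O)[O-]` carries phenyl in place of acetyl on an aromatic carbon, para to a large group (phenyl in place of acetyl on an aromatic carbon). Among the compounds with values here, no measured pair isolates this change. Compound 1, which has no acetyl, gives 2500 nM, so a small fall, not beyond the scatter, is expected, although compound 2 also lacks acetyl and goes against this. The expected step is a 1.9-fold lower number from compound 3 to compound 4 (0.28 log units; within the scatter). For compound 4 the estimated value is 3200 nM, with an expected range of 900 nM to 10000 nM.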

Compound 4, half-maximal inhibitory concentration: > 20000 nM
Compound 4 was reported as a limit; the forecaster's own chance of this, stated with the estimate: 15%; middle value at least 6.2-fold (0.79 log units) away from the limit.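

In this assay phenyl in place of acetyl on an aromatic carbon, para to a large group, gives an at least 3.2-fold higher number from compound 3 to compound 4 (0.51 log units; beyond the scatter) and thus a weaker inhibitor. Within the data shown here, this is the first step read at this place, and it shows that the larger aromatic group is not tolerated as well as acetyl. Compound 4 stands at a limit, so the step has only a lower bound: the limit of > 20000 nM in this assay, at which 1 of the 4 values shown sits.

As far as these compounds go, how far compound 4 lies past that limit stays open. So does whether an amine or a carboxylic acid on this carbon would give a stronger or a weaker inhibitor than acetyl.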